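Swapping bromo for cyano on a second core

A few compounds are considered here, and "the series" means these few. Any claim that something is new, unique, unknown or untested is made for them only; others in the source may bear on it.

Of the compounds shown here, three have been measured in an ADME assay on microsomes from liver (Mus musculus) for metabolic stability; on this read-out lower numbers stand for slow clearance and higher numbers for fast clearance. Compound 1 `COc1cc([C@](O)(CCN(C)C)[C@@H](c2cc3cc(Br)ccc3nc2OC)c2ccnc(OC)c2OC)cc(OC(F)F)n1` gives 4.9 uL/min. Compound 2 `COc1cc([C@](O)(CCN(C)C)[C@@H](c2cc3cc(C#N)ccc3nc2OC)c2ccnc(OC)c2OC)cc(OC(F)F)n1` gives 11 uL/min, and it differs from compound 1 by cyano in place of bromo on an aromatic carbon. That change produced a 2.2-fold higher number from compound 1 to compound 2 (0.35 log units; beyond the scatter). Compound 3 `CCSc1cc([C@](O)(CCN(C)C)[C@@H](c2cc3cc(Br)ccc3nc2OC)c2cccc(OC)c2F)cc(SCC)n1` gives 12 uL/min; the difference between the core of compound 3 and the core of compound 1 is not broken down here. Compound 4 `CCSc1cc([C@](O)(CCN(C)C)[C@@H](c2cc3cc(C#N)ccc3nc2OC)c2cccc(OC)c2F)cc(SCC)n1` has not yet been measured. It differs from compound 3 by cyano in place of bromo on an aromatic carbon, the same change already seen between compound 1 and compound 2, and in this series that change occurs two times in all. Among the measured compounds shown here, the expectation for compound 4 rests on the single earlier step: because a 2.2-fold higher number from compound 1 to compound 2 (0.35 log units; beyond the scatter) went upward, compound 4 is expected to show a 2.2-fold higher number from compound 3 to compound 4 (0.34 log units; beyond the scatter) from compound 3. Whether the second core responds in the same way is not known, so the range is kept wide. Compound 4 is estimated at 26 uL/min, with a likely span from 13 uL/min to 52 uL/min in this assay.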

Compound 4, intrinsic clearance in a liver preparation (reported as CLH), per the amount of preparation that the assay uses: 27 uL/min
Beside the measured number, compound 4's estimate is 1.0-fold (0.02 log units) below it; the range from low to high includes it.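

On the second core, cyano in place of bromo gave a 2.3-fold higher number from compound 3 to compound 4 (0.35 log units; beyond the scatter) in this assay, and the step matches the one seen on the first core: the same change on two cores in this assay, a 2.2-fold higher number (0.35 log units; beyond the scatter) from compound 1 to compound 2 and a 2.3-fold higher number (0.35 log units; beyond the scatter) from compound 3 to compound 4, 1.0-fold (0.00 log units) apart, within the scatter of two such steps

So, in the two pairs available, the change carried over from the core of compound 1 to the core of compound 3 with the same direction and about the same size, and neither pair goes against this. Among the compounds shown here, that is agreement between only two cores in this assay: it does not show that a third core would respond in the same way, and it does not explain why the number rises when cyano replaces bromo.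

The compounds shown leave open how other groups on this aromatic carbon, such as chloro, an amine or a carboxylic acid, would compare with bromo and cyano on either core. Going by these compounds, it also remains open which of the several differences between the two cores sets the level of their numbers.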